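Adding a Second Methoxy to the Benzyl Amide

The source may hold more compounds than are shown below. What is called first, only, known or untested is meant among the compounds shown, and "the series" means these compounds.

Measured so far:
- Compound 1, `Cc1ccc(CNC(=O)c2cccc(C(C)Oc3cccnc3Nc3cnn(CC(C)(C)O)c3)c2)cc1`, 20500 nM
- Compound 2, `COc1cccc(CNC(=O)c2cccc(C(C)Oc3ccnc(Nc4cnn(C)c4)c3)c2)c1`, 64400 nM

In a functional assay on HCC78 cells (Homo sapiens) for antiproliferative activity, read by MTT assay, with a stated time of 48 h (on this read-out lower numbers stand for stronger inhibition and higher numbers for weaker inhibition), compound 2 gives the higher of the two numbers recorded; compound 1 gives 20500 nM, and the gap between them lies beyond the scatter. The two compounds differ in more than one place, so nothing is known of any single change between them.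

Compound 3, `COc1ccc(CNC(=O)c2cccc(C(C)Oc3ccnc(Nc4cnn(C)c4)c3)c2)cc1OC`, has not yet been measured in this assay. It differs from compound 2 by methoxy in place of hydrogen on an aromatic carbon; cut one bond further out, the change reads 3-methoxybenzyl to 3,4-dimethoxybenzyl.

Among the measured compounds shown here, no measured pair shows this change, so its effect cannot be read from the numbers at hand. Compound 3 is therefore expected to land close to compound 2, with a step of a 1.3-fold lower number from compound 2 to compound 3 (0.11 log units; within the scatter) that does not clearly exceed the scatter. The estimate for compound 3 in this assay is 50000 nM, within a range from 15000 nM to 160000 nM.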

Compound 3, half-maximal inhibitory concentration: 76600 nM
Estimate against measurement, compound 3: 1.5-fold (0.19 log units) below; the measured number falls inside the stated range.
By their numbers in this assay, from the lowest: compound 1; then compounds 2 and 3 (each within the scatter of the next).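

Methoxy in place of hydrogen on this aromatic carbon, ortho to a methoxy group and para to a large group, is the first single change that can be read in this assay, and it gives a 1.2-fold higher number from compound 2 to compound 3 (0.08 log units; within the scatter). The change from 3-methoxybenzyl to 3,4-dimethoxybenzyl therefore leaves compound 2 and compound 3 indistinguishable on this read-out, so a second methoxy at this position adds no measurable difference. Nothing available on these compounds offers an explanation for this result.

Going by these compounds, it remains open whether an amine or a carboxylic acid at this same carbon would move the number beyond the scatter. On these data alone, it is also open whether the same methoxy change would behave alike on the core of compound 1.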